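A Nitrile Added to the Benzamide of Compound 2

The source may report more compounds than this note shows. Statements on the series, on what has been measured and on what is new or still open speak of the compounds shown alone.

Of the compounds shown here, two have been measured so far in an assay on isolated protein for inhibition of Rho-associated protein kinase 2 (Homo sapiens), read by scintillation counting, radiometric assay and 33P incorporation, with a stated time of 40 min, in the presence of a further agent that is not named here; on this read-out lower numbers stand for stronger inhibition and higher numbers for weaker inhibition. Compound 1 `CN(C)c1ccc(C(=O)Nc2cccc(NC(=O)COc3ccc4c(c3)CCC(=O)N4)c2)cc1` carries an extra substituent on its benzamide ring and a different core from the other compound; in this assay compound 1 gives 9970 nM. Compound 2 `O=C(COc1ccc2c(=O)ccoc2c1)Nc1cccc(NC(=O)c2ccccc2)c1` carries a plain benzamide, and in this assay compound 2 gives 16 nM. Compound 2 therefore stands at the lower of the two numbers, the stronger inhibitor, with compound 1 far higher; the two differ in more than one place, so the gap cannot be tied to any single change.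

Compound 3 `N#Cc1ccc(C(=O)Nc2cccc(NC(=O)COc3ccc4c(=O)ccoc4c3)c2)cc1` has not yet been measured. It differs from compound 2 in one place: cyano in place of hydrogen on an aromatic carbon. Within the data shown here, no measured pair here isolates the effect of a cyano group, so the direction of this step is not known from the data. A small shift, within or barely beyond the scatter, is expected, and the step is estimated as a 1.4-fold higher number from compound 2 to compound 3 (0.14 log units; within the scatter). On that basis compound 3 is expected to give about 22 nM in this assay, within a range from 6 nM to 80 nM.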

Compound 3, half-maximal inhibitory concentration: 15 nM
Estimate against measurement, compound 3: 1.5-fold (0.17 log units) above; measured number inside the range.
By their numbers in this assay, from the lowest: compounds 3 and 2 (each within the scatter of the next); then compound 1.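

Among these compounds, compound 2 and compound 3 form the first pair here that differs in one place only, so a single change can finally be read on its own. In this assay, putting cyano in place of hydrogen on the benzamide ring, para to a large group, gives a 1.1-fold lower number from compound 2 to compound 3 (0.03 log units; within the scatter), so the two compounds cannot be told apart. This shows that this ring carbon can carry cyano, with its 2 heavy atoms and its hydrogen-bond acceptor, without a change that can be read in this assay, though nothing measured here explains that result.

On these data alone, one substituent at one place says little about others, so it remains open whether a carboxylic acid or a longer chain such as butyl on the same carbon would also leave the number where it is. The much higher number of compound 1 also remains unexplained, as that compound differs from compound 2 in more than one place and its gap cannot be assigned to either its ring substituent or its core.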